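The source may report more compounds than this note shows. Statements on the series, on what has been measured and on what is new or still open speak of the compounds shown alone.

Working notes on the series. Among the compounds with values here, in a functional assay on HL-60 cells (Homo sapiens) for antiproliferative activity (on this read-out higher numbers stand for weaker inhibition and lower numbers for stronger inhibition), compound 1 (`CCOC(=O)c1ccc(Oc2ccc(OC)c(F)c2)cc1`) gives 3500 nM, the only actual number so far. Compound 2 (`CCOC(=O)c1ccc(Oc2ccc(OC)c(OC)c2)cc1`) reads > 20000 nM, which is a limit and not a number. Compound 3 (`CCOC(=O)c1ccc(Oc2ccc(F)c(F)c2)cc1`) reads > 30000 nM, also a limit.

Compound 4 (`CCOC(=O)c1ccc(Oc2ccc(OC)c(F)c2)cc1O`) is the next to be read, and it departs from compound 1 as follows: hydroxy in place of hydrogen on an aromatic carbon. In words, this is hydroxy in place of hydrogen on an aromatic carbon.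

Two measured steps offer indirect guidance: an at least 5.7-fold higher number from compound 1 to compound 2 (0.75 log units; beyond the scatter) and an at least 8.5-fold higher number from compound 1 to compound 3 (0.93 log units; beyond the scatter). Both are methoxy and fluoro exchanges, both lie beyond the scatter, and both are open-ended. Within the data shown here, neither alters the aromatic ring carrying the ethoxycarbonyl group, so no measured step shows what hydroxy does there. Among the measured compounds shown here, they show only that compound 1, at 3500 nM, lost activity with each of the two changes tried. On that thin basis, a modest move towards weaker inhibition in this assay is expected, though a result within the scatter remains plausible. The expected step is a 1.4-fold higher number from compound 1 to compound 4 (0.15 log units; within the scatter). For compound 4, the estimated value is 5000 nM, with an expected range from 1200 nM to 20000 nM.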

Compound 4, half-maximal inhibitory concentration: > 30000 nM
Compound 4 gave a limit, no number (the forecaster's own chance of this, stated with the estimate: 20%); at least 6.0-fold (0.77 log units) between middle value and limit.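

Hydroxy in place of hydrogen, ortho to the ethoxycarbonyl group, is the first change in the series on the ring carrying that group, and in this assay it gives an at least 8.5-fold higher number from compound 1 to compound 4 (0.93 log units; beyond the scatter). Compound 4 reads > 30000 nM, which is a limit and not a number, so the step is open-ended and its true size cannot be read. Compound 1 therefore loses activity not only with the methoxy and fluoro exchanges on its other aromatic ring but also with this single added group on the ring carrying the ethoxycarbonyl group, and compound 4 sits at a limit shared with one other compound: the limit of > 30000 nM in this assay, at which 2 of the 4 values shown sit.

The compounds shown hold only hydroxy at this position, so whether a methoxy, a fluoro or an amine there would retain the activity of compound 1 at 3500 nM stays open. Also open, as far as these compounds go, is how hydroxy would read on the other carbons of this ring, and whether a carboxylic acid or an amide in place of the ethoxycarbonyl group would change the picture.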